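A Benzylamino Swap Without a Measured Starting Point

The source may report more compounds than this note shows. Statements on the series, on what has been measured and on what is new or still open speak of the compounds shown alone.

Going by the values given here, only one number anchors this series. In an ADME assay on microsomes from liver (Homo sapiens) for metabolic stability, with a stated time of 30 min (on this read-out lower numbers stand for a less stable compound and higher numbers for a more stable compound), compound 1 (`CC(C)(C)[C@@H](CO)n1cc(C(=O)O)c(=O)c2cc(Cc3cccc(Cl)c3F)c(OCCO)nc21`) gives 45%. Compound 2 (`COc1nc2c(cc1Nc1ccc(Cl)c(F)c1)c(=O)c(C(=O)O)cn2[C@H](CO)C(C)C`) has no such number, and in this assay compound 2 is recorded as "not determined" (no result reported), so its standing cannot be placed on the scale. Compound 3 (`COc1nc2c(cc1NCc1ccc(F)cc1F)c(=O)c(C(=O)O)cn2[C@H](CO)C(C)C`) awaits measurement. The structural change is 2,4-difluorobenzyl in place of 4-chloro-3-fluorophenyl on a nitrogen on an aromatic ring. Among the compounds with values here, no measured step shows what such a change does, so no step beyond the usual scatter, in either direction, is expected in this assay. The expectation therefore rests on compound 1 at 45%, and it remains loose. Compound 3 is expected at 45%, with an estimated range from 15% to 80%.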

Compound 3, percent of the compound remaining: 87%
Compound 3: middle estimate off by 42 percentage points, on the low side; measured number outside the range, above it.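

No step can be read between compound 2 and compound 3: in this assay compound 2 has no single number, while compound 3 gives 87%. The compounds shown leave open what (2,4-difluorobenzyl)amino in place of (4-chloro-3-fluorophenyl)amino does on this read-out. No evidence shown bears on this result.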